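The source may report more compounds than this note shows. Statements on the series, on what has been measured and on what is new or still open speak of the compounds shown alone.

Compound 3 `COc1ccc(CN2CCN(c3nc(Nc4ccc(C#N)c(C(F)(F)F)c4)nc(Oc4ccnc5ccccc45)n3)CC2)c(OC)c1OC` stands at the weak end of the series, where in a functional assay on DU-145 cells (Homo sapiens) for cytotoxicity, read by sulforhodamine B assay, with a stated time of 48 h (on this read-out lower numbers stand for stronger inhibition of growth and higher numbers for weaker inhibition of growth), compound 3 gives > 100000 nM, which is a limit of the assay and not a number, as noted for (the limit of > 100000 nM in this assay, at which 1 of the 3 values shown sits). Compound 1 `N#Cc1ccc(Nc2nc(Oc3ccnc4ccccc34)nc(N3CCN(c4ccccc4Cl)CC3)n2)cc1C(F)(F)F` gives 92600 nM in this assay, and compound 2 `CC(=O)N1CCN(c2nc(Nc3ccc(C#N)c(C(F)(F)F)c3)nc(Oc3ccnc4ccccc34)n2)CC1` gives 75100 nM. For the measured compounds named here, the one measured step, a 1.2-fold lower number from compound 1 to compound 2 (0.09 log units; within the scatter), sits at the amine nitrogen in the ring and not at the saturated chain carbon. Compound 4 `N#Cc1ccc(Nc2nc(Oc3ccnc4ccccc34)nc(N3CCN(Cc4ccccc4)CC3)n2)cc1C(F)(F)F` differs from compound 3 by phenyl in place of 2,3,4-trimethoxyphenyl on a saturated chain carbon bound to an amine nitrogen in a ring. Going by the values given here, no measured step covers this change, so no shift beyond the scatter is expected, and the number for compound 4 is expected to stay in the weak range of compounds 1 and 2. Compound 4 is estimated at 90000 nM, between 40000 nM and 200000 nM, which as a step would mean an at least 1.1-fold lower number from compound 3 to compound 4 (0.04 log units; that floor lies within the scatter).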

Compound 4, concentration for 50% growth inhibition: > 100000 nM
Compound 4 was reported as a limit (the forecaster's own chance of this, stated with the estimate: 40%); at least 1.1-fold (0.04 log units) between middle value and limit.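

In this assay compound 4 gives > 100000 nM which is a limit of the assay and not a number. With phenyl in place of 2,3,4-trimethoxyphenyl, the step from compound 3 cannot be read because both values are limits: the limit of > 100000 nM in this assay, at which 2 of the 4 values shown sit. The steps of an at least 1.3-fold higher number from compound 2 to compound 4 (0.12 log units; that floor lies within the scatter) and an at least 1.0-fold higher number from compound 1 to compound 4 (0.03 log units; that floor lies within the scatter) have floors within the scatter, so benzyl on the amine nitrogen in a ring is not separated from acetyl or 2-chlorophenyl.

On these data alone, how far compound 3 and compound 4 lie past the limit stays open. So does the read-out for a carboxylic acid or a longer chain in place of phenyl on this saturated chain carbon.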